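Adding a fluoro to compound 2

The source may report more compounds than this note shows. Statements on the series, on what has been measured and on what is new or still open speak of the compounds shown alone.

In a functional assay on HeLa cells (Homo sapiens) for antiproliferative activity, read by MTT assay, with a stated time of 48 h (a lower number here means a stronger inhibitor, a higher number a weaker inhibitor), compound 1 (`Fc1ccc2[nH]c(-c3cn(-c4ccccc4)nc3-c3ccccc3)nc2c1`) gives 3610 nM while compound 2 (`Clc1ccc(-c2nn(-c3ccccc3)cc2-c2nc3ccccc3[nH]2)cc1`) gives 1650 nM and so holds the lower of the two numbers, by a gap beyond the usual scatter. These two compounds differ in more than one place, so that gap cannot be assigned to any single change. Compound 3 (`Fc1ccc2[nH]c(-c3cn(-c4ccccc4)nc3-c3ccc(Cl)cc3)nc2c1`) is compound 2 with one change (fluoro in place of hydrogen on an aromatic carbon): fluoro in place of hydrogen on an aromatic carbon. Going by the values given here, no measured pair shows this change alone. The best starting point is therefore compound 2 at 1650 nM with only a slight rise expected in this assay and nothing beyond the scatter. The estimated 1.2-fold higher number from compound 2 to compound 3 (0.06 log units; within the scatter) is expected to stay small. Compound 3 is expected near 1900 nM in this assay (estimated range 800 nM to 4000 nM).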

Compound 3, half-maximal inhibitory concentration: 2770 nM
The estimate for compound 3 lay 1.5-fold (0.16 log units) below the measured number; the range from low to high includes it.
By their numbers in this assay, from the lowest: compounds 2, 3 and 1 (each within the scatter of the next, the first and the last beyond it).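

In this assay, fluoro in place of hydrogen on an aromatic carbon of the fused two-ring system gives a 1.7-fold higher number from compound 2 to compound 3 (0.22 log units; within the scatter) and so does not clearly shift the number, while putting a chloro where a hydrogen stood gives a 1.3-fold lower number from compound 1 to compound 3 (0.12 log units; within the scatter) and likewise leaves the number within the scatter. Compound 3 thus joins compound 1 and compound 2, which differ in two places, through two single changes, and neither change taken alone can be held responsible for the clear gap between those two compounds. No measurement in hand explains these numbers.

Still open, as far as these compounds go, is whether a larger group at the fluoro position, such as an amine or a carboxylic acid, would move the number beyond the scatter. Also open, from the compounds shown here alone, is whether either halogen matters more when the other is absent or replaced.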